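The source may report more compounds than this note shows. Statements on the series, on what has been measured and on what is new or still open speak of the compounds shown alone.

Compound 1 `COc1c(Br)cccc1C(=O)Nc1ccc(Sc2nc3ccccc3s2)c(Cl)c1` gives > 100000 nM in an assay on isolated protein for inhibition of thiosulfate sulfurtransferase (Homo sapiens), with a stated time of 60 min, in the absence of a further agent; on this read-out lower numbers stand for stronger inhibition and higher numbers for weaker inhibition.
Compound 2 `COc1ccccc1C(=O)Nc1ccc(Sc2nc3ccccc3s2)c(Cl)c1` gives > 100000 nM in this assay.
Compound 3 `O=C(Nc1ccc(Sc2nc3ccccc3s2)c(Cl)c1)c1ccccc1` gives > 100000 nM in this assay.

For compound 1 the value shown is a limit of the assay, not a measured number. The value of compound 2 is likewise a limit. The value of compound 3 is a limit as well. Because of the limit of > 100000 nM in this assay, at which 3 of the 3 values shown sit, none of the three compounds can be placed above or below the others, and compound 1 simply stands at that limit with the other two.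

The steps between the measured compounds follow from this: a step that the two limits leave unreadable from compound 1 to compound 2, a step that the two limits leave unreadable from compound 1 to compound 3 and a step that the two limits leave unreadable from compound 2 to compound 3. Each of them changes the ring on the carbonyl carbon, and none gives a readable size.

Compound 4 `COc1c(Br)cccc1C(=O)Nc1ccc(Sc2nc3ccccc3s2)cc1` differs from compound 1 elsewhere, on the ring bearing the amide nitrogen: hydrogen in place of chloro on an aromatic carbon. Within the data shown here, no measured step touches this position, and the steps that exist are all unreadable, so they offer no direction for this change. Among the measured compounds shown here, the only guide is that all three measured compounds sit at the limit. Compound 4 is therefore expected to give about 200000 nM, with a range from 60000 nM to 700000 nM. This estimate corresponds to an expected step that the limit leaves unreadable from compound 1 to compound 4, most likely reported again as a limit rather than a number.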

Compound 4, half-maximal inhibitory concentration: > 100000 nM
Compound 4 ended at the assay's limit (the forecaster's own chance of this, stated with the estimate: 85%); the middle value is on the limit's open side.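

The step from compound 1 to compound 4 cannot be read, because the values of both compounds are limits rather than numbers: the limit of > 100000 nM in this assay, at which 4 of the 4 values shown sit.

The compounds shown leave open how far these four compounds lie from one another in this assay, and whether the chloro or the ring on the carbonyl carbon has any bearing on inhibition.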